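The compounds below may be only part of what the source reports. "The series", "measured", "known", "first", "only" and "open" are said of these compounds alone.

Measured compounds:
Compound 1, `COc1ccc(/C=C/C(=O)Nc2nc3ccccc3s2)cc1O`: 495 umol/kg
Compound 2, `COc1ccc(C2CC(Nc3nc4ccccc4s3)=NN2C(C)=O)cc1`: 226 umol/kg
Compound 3, `COc1ccc(C2CC(Nc3nc4ccc(Cl)cc4s3)=NN2C(C)=O)cc1`: 93.3 umol/kg

All three were tested in a functional assay on the whole organism (Hindlimb, strain albino) with Mus musculus as the target, in the maximal electroshock model, with a stated time of 0.5 h; on this read-out lower numbers stand for an effect already at smaller amounts and higher numbers for an effect only at larger amounts of compound. Compound 1 stands highest of the three numbers, and the two compounds built on the other core both lie beyond the usual scatter below it. Compound 2 and compound 3 share a core that differs from the core of compound 1; the difference between the two cores is not broken down here. Within the shared core, the single change is chloro in place of hydrogen on an aromatic carbon, and it gave a 2.4-fold lower number from compound 2 to compound 3 (0.38 log units; beyond the scatter).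

Compound 4, `COc1ccc(/C=C/C(=O)Nc2nc3ccc(Cl)cc3s2)cc1O`, has not yet been measured in this assay. It carries the same change relative to compound 1: chloro in place of hydrogen on an aromatic carbon. For the measured compounds named here, because the one measured step of this kind, a 2.4-fold lower number from compound 2 to compound 3 (0.38 log units; beyond the scatter), was modest but beyond the scatter, a step of similar size is expected here. Compound 4 is therefore estimated at 230 umol/kg, between 120 umol/kg and 450 umol/kg. This means an expected step of a 2.2-fold lower number from compound 1 to compound 4 (0.33 log units; beyond the scatter).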

Compound 4, dose for half-maximal effect: 320 umol/kg
The estimate for compound 4 lay 1.4-fold (0.14 log units) below the measured number, within the range that was stated.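

In this assay, chloro in place of hydrogen on an aromatic carbon gave a 1.5-fold lower number from compound 1 to compound 4 (0.19 log units; within the scatter) on the core of compound 1, so on this core the step does not stand clear of the scatter. Set beside the earlier step, it does not differ from it by more than two such steps can scatter: the same change on two cores in this assay, a 2.4-fold lower number (0.38 log units; beyond the scatter) from compound 2 to compound 3 and a 1.5-fold lower number (0.19 log units; within the scatter) from compound 1 to compound 4, 1.6-fold (0.19 log units) apart, within the scatter of two such steps.
The two cores thus show no measurable difference for this change, but with one pair on each core this does not establish that the step has the same size on both, or that it exists at all on the core of compound 1.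

The compounds shown leave open how a fluoro group, a methyl group or an amine would behave at this place on either core. They also leave open whether the two cores would still agree for such groups.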